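This account rests on a few compounds, and the source may have more. Where it says the series, first, only, none or still open, it means among the compounds named here.

Measured so far:
- compound 1 `Oc1ccc(/C=N\NC(=S)NC2CCCCC2)c(O)c1` — in a functional assay on MCF7 cells (Homo sapiens) for inhibition, read by WST assay, with a stated time of 48 h (on this read-out lower numbers stand for stronger inhibition and higher numbers for weaker inhibition), compound 1 gives 105000 nM
- compound 2 `COc1cccc(/C=N\NC(=S)NC2CCCCC2)c1` — in this assay compound 2 gives 49900 nM
- compound 3 `CCOc1ccc(/C=N\NC(=S)NC2CCCCC2)cc1` — in this assay compound 3 gives 166000 nM

Compound 3 and compound 1 lie within the scatter of each other; compound 2 gives a number lower than compound 3 by a gap beyond the scatter. All three numbers are high.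

Compound 4 `S=C(N/N=C\c1ccc(Cl)cc1)NC1CCCCC1` is not yet measured. It differs from compound 3 by chloro in place of ethoxy on an aromatic carbon. Among the compounds with values here, no pair of measured compounds shares this change, so nothing measured sets its size. A modest step toward a lower number is expected, though a step within the scatter is also plausible. Compound 4 is expected to give 90000 nM in this assay, with a range from 25000 nM to 300000 nM. The expected step is a 1.8-fold lower number from compound 3 to compound 4 (0.27 log units; within the scatter).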

Compound 4, half-maximal inhibitory concentration: 91400 nM
Compound 4: the middle estimate sits 1.0-fold (0.01 log units) below what was measured, and the stated range covers the measured number.
By their numbers in this assay, from the lowest: compounds 2, 4, 1 and 3 (each within the scatter of the next, the first and the last beyond it).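

In this assay, within the data shown here, chloro in place of ethoxy on an aromatic carbon, para to a large group, gives a 1.8-fold lower number from compound 3 to compound 4 (0.26 log units; within the scatter) as the first readable step at this position. Ethoxy and chloro are therefore not separated by this read-out here, although they differ in size and in hydrogen-bond acceptor count, and both numbers remain high. No measurement on hand accounts for this result.

As far as these compounds go, whether any group at this position can move the number beyond the scatter stays open. An amine, a carboxylic acid or a longer alkoxy chain would test this.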